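A few compounds are considered here, and "the series" means these few. Any claim that something is new, unique, unknown or untested is made for them only; others in the source may bear on it.

For the measured compounds named here, in a functional assay on MCF-10A cells (Homo sapiens) for antiproliferative activity, with a stated time of 48 h (a lower number here means that less compound is needed, a higher number that more compound is needed for the effect), compound 1 (`COc1ccc2nc(C)cc(NCc3ccc(OC)c(F)c3)c2c1`) gives 10300 nM and compound 2 (`CCCOc1ccc2nc(C)cc(NCc3ccc(F)cc3)c2c1`) gives 14300 nM, so compound 2 stands within the usual scatter of the only other number available. Compound 3 (`Cc1cc(NCc2ccc(F)cc2)c2cc(OCCCCCCO)ccc2n1`) turns the propyl of compound 2 into 6-hydroxyhexyl: 3-hydroxypropyl in place of hydrogen on a saturated chain carbon, three bonds along the chain from an oxygen on an aromatic ring. Going by the values given here, no measured pair of compounds differs in just one place, so no measured step guides this change. No shift beyond the scatter is expected, and the estimated change is a 1.3-fold lower number from compound 2 to compound 3 (0.11 log units; within the scatter). For compound 3 the expected value is 11000 nM, with an estimated range of 4000 nM to 30000 nM.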

Compound 3, half-maximal effective concentration: 11300 nM
Estimate against measurement, compound 3: 1.0-fold (0.01 log units) below, and the stated range covers the measured number.
By their numbers in this assay, from the lowest: compounds 1, 3 and 2 (each within the scatter of the next).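

In this assay, the step gives a 1.3-fold lower number from compound 2 to compound 3 (0.10 log units; within the scatter) and so stays within the scatter: at this position, the long 6-hydroxyhexyl chain gives much the same number as propyl. For the compounds shown here, this is the first comparison of compounds that differ in only one place, and it shows that this added length and terminal hydroxyl do not shift the number beyond the scatter. Nothing measured here offers an explanation for this result.

Still open, on these data alone, is whether plain hexyl, or a chain ending in an amine or a carboxylic acid, would give a similar number.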